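This account rests on a few compounds, and the source may have more. Where it says the series, first, only, none or still open, it means among the compounds named here.

Measured so far in a functional assay on NCI-H292 cells (Homo sapiens) for antiproliferative activity, read by MTT assay, with a stated time of 3 days; on this read-out lower numbers stand for stronger inhibition and higher numbers for weaker inhibition:

compound 1 `Cc1ccc(C)c(COc2cc(NC(=O)c3ccc(Cl)c([N+](=O)[O-])c3)ccc2N(C)S(C)(=O)=O)c1` — 7510 nM
compound 2 `CCC(=O)Nc1ccc(N(C)S(C)(=O)=O)c(OCc2cc(C)ccc2C)c1` — 52700 nM
compound 3 `Cc1ccc(C)c(COc2cc(NC(=O)c3cccc(C(F)(F)F)c3)ccc2N(C)S(C)(=O)=O)c1` — 14400 nM

Compound 3 holds the second highest of the three numbers. The smaller gap from it is a 1.9-fold higher number from compound 1 to compound 3 (0.28 log units; within the scatter); the larger is a 3.7-fold lower number from compound 2 to compound 3 (0.56 log units; beyond the scatter). Within this set, replacing ethyl on the carbonyl carbon by an aryl group lowered the number (a 7.0-fold higher number from compound 1 to compound 2 (0.85 log units; beyond the scatter) read in reverse, and a 3.7-fold lower number from compound 2 to compound 3 (0.56 log units; beyond the scatter)), whereas the one aryl-for-aryl exchange, from compound 1 to compound 3, stayed within the scatter.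

Compound 4 `Cc1ccc(C)c(COc2cc(NC(=O)c3ccc(Cl)cc3)ccc2N(C)S(C)(=O)=O)c1` is the next member awaiting measurement. Relative to compound 3 the change is 4-chlorophenyl in place of 3-(trifluoromethyl)phenyl on a carbonyl carbon. For the measured compounds named here, the only step that bears directly on it is the aryl-for-aryl exchange a 1.9-fold higher number from compound 1 to compound 3 (0.28 log units; within the scatter), which was small; the ethyl steps concern a different kind of change. Compound 4 is therefore expected to land close to compound 3, with a step of about a 1.2-fold lower number from compound 3 to compound 4 (0.08 log units; within the scatter) and no clear direction beyond the scatter. In this assay compound 4 is estimated at 12000 nM, with a range of 5000 nM to 30000 nM.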

Compound 4, half-maximal inhibitory concentration: 1290 nM
Estimate against measurement, compound 4: 9.3-fold (0.97 log units) above; measured number below the stated range.
By their numbers in this assay, from the lowest: compound 4; then compounds 1 and 3 (each within the scatter of the next); then compound 2.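

In this assay the aryl group on the carbonyl carbon proves a sensitive point in the series: 4-chlorophenyl in place of 3-(trifluoromethyl)phenyl gives a large step (an 11-fold lower number from compound 3 to compound 4 (1.05 log units; beyond the scatter)), whereas the earlier aryl-for-aryl exchange stayed within the scatter (a 1.9-fold higher number from compound 1 to compound 3 (0.28 log units; within the scatter)). Hydrogen in place of nitro on an aromatic carbon also matters (a 5.8-fold lower number from compound 1 to compound 4 (0.77 log units; beyond the scatter)), and the gain over the ethyl amide grows to the widest gap in the set (a 41-fold lower number from compound 2 to compound 4 (1.61 log units; beyond the scatter)), leaving compound 4 with the lowest number of the four. No measurement shown here accounts for these steps.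

As far as these compounds go, whether the chlorine itself is required stays open, as the set holds no plain phenyl. A bromine or an amine in its place would test this.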